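Replacing the hydrazine arm of compound 1

The source may hold more compounds than are shown below. What is called first, only, known or untested is meant among the compounds shown, and "the series" means these compounds.

Compound 1 `Cc1ccccc1-c1nnc(NN)s1` was tested in a functional assay on the whole organism with Mus musculus as the target, in the maximal electroshock model, with a stated time of 1 h; on this read-out higher numbers stand for an effect only at larger amounts of compound and lower numbers for an effect already at smaller amounts. In this assay compound 1 gives only a limit of > 100 mg/kg, which is the end of the tested range and not a measured number. Compound 2 `Cc1ccccc1-c1nnc(NNC2CCCC2)s1` differs from compound 1 by cyclopentyl in place of hydrogen on an amine nitrogen, and compound 3 `Cc1ccccc1-c1nnc(NNc2ccccc2)s1` by phenyl in place of hydrogen on an amine nitrogen. In this assay compound 2 likewise gives a limit of > 100 mg/kg. In this assay compound 3 also gives a limit of > 100 mg/kg. Because all three values sit at the limit of > 100 mg/kg in this assay, at which 3 of the 3 values shown sit, the step that the two limits leave unreadable from compound 1 to compound 2, the step that the two limits leave unreadable from compound 1 to compound 3 and the step that the two limits leave unreadable from compound 2 to compound 3 cannot be given a size or a direction.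

Compound 4 `Cc1ccccc1-c1nnc(N(C)NC(C)C)s1` carries the change (isopropylamino)(methyl)amino in place of aminoamino on an aromatic carbon: the group that leaves is aminoamino, the group that enters is (isopropylamino)(methyl)amino. For the measured compounds named here, no measured step bears on this change with a readable size, as each measured step runs between two limits. The expectation for compound 4 therefore rests on the limits alone, and compound 4 is expected at 100 mg/kg, within 40 mg/kg to 300 mg/kg, most probably again reported as a limit. The expected step of a number no higher from compound 1 to compound 4 (the limit leaves the size open) is accordingly none beyond the scatter.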

Compound 4, dose for half-maximal effect: 35 mg/kg
Compound 4: middle estimate off by 2.9-fold (0.46 log units), on the high side; the measured number lies below the stated range.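

The three earlier compounds left every step between them unreadable, so they could not show whether the arm on this aromatic carbon responds to change at all. In this assay, replacing aminoamino with (isopropylamino)(methyl)amino gives an at least 2.8-fold lower number from compound 1 to compound 4 (0.45 log units; beyond the scatter), the first readable sign that the group at this place matters for the effect in mice. Compound 4 also gives the series its first real number, a firmer starting point for further comparisons, but the step can be stated only as a minimum because compound 1 stands at a limit and not at a measured number: the limit of > 100 mg/kg in this assay, at which 3 of the 4 values shown sit.

The entering group differs from the one leaving in two ways at once, with a methyl and an isopropyl, and the compounds shown cannot tell which of them, or whether only the two together, accounts for the step. Also open, on these data alone, is how far the effect carries over to other groups at this place, such as a longer chain like butyl on the same nitrogen or a ring amine like piperidine.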